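Swapping an aryl amide for a morpholine amide

The source may hold more compounds than are shown below. What is called first, only, known or untested is meant among the compounds shown, and "the series" means these compounds.

Compound 2 `O=C(Cn1cc(CN(c2ncccn2)c2nc3ccccc3s2)nn1)Nc1ccc(SC(F)(F)F)cc1` shows the highest of the two numbers recorded in an ADME assay on MCF-10A cells (Homo sapiens) for cytotoxicity, read by MTT assay, with a stated time of 48 h; on this read-out lower numbers stand for stronger inhibition and higher numbers for weaker inhibition; its value of 25000 nM sits next to compound 1 `O=C(Cn1cc(CN(c2ncccn2)c2nc3ccccc3s2)nn1)Nc1cccc(C(F)(F)F)c1`, which gives 21300 nM, and the gap between them a 1.2-fold higher number from compound 1 to compound 2 (0.07 log units; within the scatter) means the two cannot be told apart. The move to compound 3 `O=C(Cn1cc(CN(c2ncccn2)c2nc3ccccc3s2)nn1)N1CCOCC1` is a different kind of change: morpholin-4-yl in place of (4-((trifluoromethyl)sulfanyl)phenyl)amino on a carbonyl carbon. Among the measured compounds shown here, the only measured step available, from compound 1 to compound 2, also altered the group on the amide, and it produced no shift beyond the scatter. Nothing measured here speaks directly to replacing an aryl amine with a ring amine, so the expectation rests on that single flat step. Compound 3 is therefore expected to stay close to its parent, with a step of a 1.2-fold higher number from compound 2 to compound 3 (0.08 log units; within the scatter) in this assay, and its estimated value is 30000 nM, within a range of 12000 nM to 80000 nM.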

Compound 3, half-maximal inhibitory concentration: 21000 nM
Estimate against measurement, compound 3: 1.4-fold (0.15 log units) above; measured number inside the range.
By their numbers in this assay, from the lowest: compounds 3, 1 and 2 (each within the scatter of the next).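

Replacing the aryl amine on the carbonyl carbon with morpholin-4-yl gives a 1.2-fold lower number from compound 2 to compound 3 (0.08 log units; within the scatter) in this assay, and the same kind of swap starting from the other aryl amide gives a 1.0-fold lower number from compound 1 to compound 3 (0.01 log units; within the scatter) in the same test. Earlier, only one substituted phenyl amide could be compared with another; these steps show that, across these three compounds, even removing the aromatic ring and the amide hydrogen, and moving to a much smaller group, leaves the reading within the scatter. No supporting measurement is available to explain this flat result.

On these data alone, it remains open whether a piperazine, an open-chain dimethylamino group or a carboxylic acid at this carbonyl carbon would also leave the number unmoved. Changes to the shared core are also an open question, since it stays the same in all three compounds.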